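The source may hold more compounds than are shown below. What is called first, only, known or untested is meant among the compounds shown, and "the series" means these compounds.

In an ADME assay on microsomes from liver (Rattus norvegicus) for metabolic stability (a lower number here means slower removal, a higher number faster removal of the compound), three compounds have been measured. Compound 1 `CNc1nc(NC)nc(NC2(C#N)CCCCC2)n1` gives 210 mL/min/kg, compound 2 `CCC(C)(C#N)Nc1nc(NC)nc(-n2cncn2)n1` gives 32 mL/min/kg and compound 3 `CNc1nc(NC2(C#N)CCCC2)nc(-n2cncn2)n1` gives 43 mL/min/kg. Compound 3 thus holds the second highest of the three numbers, within the scatter of compound 2 and well under compound 1. Compound 4 `C#CC(CC)(CC)Nc1nc(NC)nc(-n2cncn2)n1` has not yet been measured. It differs from compound 3 as follows: 1,1-diethylprop-2-yn-1-yl in place of 1-cyanocyclopentyl on a nitrogen on an aromatic ring. In short, 1,1-diethylprop-2-yn-1-yl stands in place of 1-cyanocyclopentyl on a nitrogen on an aromatic ring. Among the measured compounds shown here, only one measured step touches this place: a 1.3-fold higher number from compound 2 to compound 3 (0.13 log units; within the scatter). For the measured compounds named here, that step is small, but both of its groups are cyano-bearing, so no measured step shows what follows when the nitrile is gone. Differing from the others in more than one place, compound 1 at 210 mL/min/kg is only a loose upper guide. A moderate rise in this assay is therefore expected, with wide uncertainty. The expected change is a 1.9-fold higher number from compound 3 to compound 4 (0.27 log units; within the scatter). For compound 4 the estimated clearance is 80 mL/min/kg, with an expected range from 35 mL/min/kg to 190 mL/min/kg.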

Compound 4, clearance: 22 mL/min/kg
Beside the measured number, compound 4's estimate is 3.6-fold (0.56 log units) above it; measured number outside the range, below it.
By their numbers in this assay, from the lowest: compounds 4, 2 and 3 (each within the scatter of the next); then compound 1.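

In this assay the nitrile at this position, on a nitrogen on an aromatic ring, proves not to be needed for the number to stay where it was: 1,1-diethylprop-2-yn-1-yl in place of 1-cyanocyclopentyl gives a 2.0-fold lower number from compound 3 to compound 4 (0.29 log units; within the scatter) and, in place of 1-cyano-1-methylpropyl, gives a 1.5-fold lower number from compound 2 to compound 4 (0.16 log units; within the scatter) for the same swap on an open-chain group. The three groups at this place, with or without a nitrile and with or without a ring, thus all lie within the scatter of one another on this core. No measured evidence is at hand that would account for this result.

Going by these compounds, whether a group carrying an amine or a carboxylic acid, or a longer chain, would stay in the same range at this position remains open. On these data alone, it is also open whether 1,1-diethylprop-2-yn-1-yl would behave in the same way on the core of compound 1, which gives 210 mL/min/kg with its 1-cyanocyclohexyl-type group.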